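Swapping the nitroimidazole chain of compound 2

This account rests on a few compounds, and the source may have more. Where it says the series, first, only, none or still open, it means among the compounds named here.

In a functional assay on HT-29 cells (Homo sapiens) for inhibition, read by sulforhodamine B assay, with a stated time of 72 h (on this read-out higher numbers stand for weaker inhibition and lower numbers for stronger inhibition), compound 1 (`COc1cc2c(Nc3ccc(F)c(Cl)c3)ncnc2cc1OCCOCCn1ccnc1[N+](=O)[O-]`) gives 5520 nM and compound 2 (`C#Cc1cccc(Nc2ncnc3cc(OCCCCCn4ccnc4[N+](=O)[O-])c(OC)cc23)c1`) gives 280 nM. Compound 2 holds the lower of the two numbers, a gap beyond the scatter. Compound 3 (`C#Cc1cccc(Nc2ncnc3cc(OCCOCCn4ccnc4[N+](=O)[O-])c(OC)cc23)c1`) alters compound 2 as follows: 2-(2-nitro-1H-imidazol-1-yl)ethoxy in place of 3-(2-nitro-1H-imidazol-1-yl)propyl on a saturated chain carbon, two bonds along the chain from an oxygen on an aromatic ring. Within the data shown here, no measured step isolates this change in this assay. Compound 1 also carries 2-(2-nitro-1H-imidazol-1-yl)ethoxy and reads 5520 nM, so a moderate rise in the number, beyond the scatter, is expected. The expected step is a 3.2-fold higher number from compound 2 to compound 3 (0.51 log units; beyond the scatter). For compound 3 the estimated value is 900 nM, with an expected range of 250 nM to 3500 nM.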

Compound 3, half-maximal inhibitory concentration: 6040 nM
For compound 3 the middle estimate is 6.7-fold (0.83 log units) below the measured one, outside the stated range (above it).
By their numbers in this assay, from the lowest: compound 2; then compounds 1 and 3 (each within the scatter of the next).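

In this assay, this position on the chain is sensitive: 2-(2-nitro-1H-imidazol-1-yl)ethoxy in place of 3-(2-nitro-1H-imidazol-1-yl)propyl gives a 22-fold higher number from compound 2 to compound 3 (1.33 log units; beyond the scatter) and removes the advantage held by compound 2. With the 2-(2-nitro-1H-imidazol-1-yl)ethoxy chain fixed, 3-ethynylphenyl in place of 3-chloro-4-fluorophenyl gives a 1.1-fold higher number from compound 1 to compound 3 (0.04 log units; within the scatter) as the step on the nitrogen. No supporting data explain the chain step. Open, going by these compounds, is how 3-chloro-4-fluorophenyl reads with the 3-(2-nitro-1H-imidazol-1-yl)propyl chain, and whether a longer chain or a terminal amine would hold the number of compound 2.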